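Anilino variation on the shared core against ECa-109 cells

This account rests on a few compounds, and the source may have more. Where it says the series, first, only, none or still open, it means among the compounds named here.

Working notes on the anilino substituent of the shared core. Three compounds have numbers in a functional assay on ECa-109 cells (Homo sapiens) for inhibition, read by MTT assay, with a stated time of 72 h; a higher number here means a weaker inhibitor, a lower number a stronger inhibitor. Compound 1 `COc1ccc(Nc2nc(SCc3cn(Cc4ccccc4Cl)nn3)nc(-c3ccccc3)c2C#N)cc1` gives 7960 nM. Compound 2 `N#Cc1c(Nc2cccc(C(F)(F)F)c2)nc(SCc2cn(Cc3ccccc3Cl)nn2)nc1-c1ccccc1` gives 32000 nM and compound 3 `N#Cc1c(Nc2cccc(Cl)c2)nc(SCc2cn(Cc3ccccc3Cl)nn2)nc1-c1ccccc1` gives 24400 nM. Compound 3 holds the second highest number of the three; its value and that of compound 2 lie within the scatter of each other, while a 3.1-fold higher number from compound 1 to compound 3 (0.49 log units; beyond the scatter) is beyond it, as is a 4.0-fold higher number from compound 1 to compound 2 (0.60 log units; beyond the scatter).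

Compound 4 `COc1ccccc1Nc1nc(SCc2cn(Cc3ccccc3Cl)nn2)nc(-c2ccccc2)c1C#N` is the next candidate. The change is 2-methoxyphenyl in place of 3-chlorophenyl on a nitrogen on an aromatic ring. Going by the values given here, the only step that bears on it is the one between compound 1 and compound 3, where a methoxyphenyl gave the lower number; compound 4 carries a methoxyphenyl again, though with the methoxy in a different position, so the size of that step cannot simply be carried over. A move back toward the number of compound 1 is expected, but a smaller one: for compound 4 the expected step is a 2.0-fold lower number from compound 3 to compound 4 (0.31 log units; beyond the scatter), giving an estimate of 12000 nM in this assay, with a range from 3500 nM to 40000 nM.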

Compound 4, half-maximal inhibitory concentration: 9670 nM
Compound 4: middle estimate off by 1.2-fold (0.09 log units), on the high side; the measured number falls inside the stated range.
By their numbers in this assay, from the lowest: compounds 1 and 4 (each within the scatter of the next); then compounds 3 and 2 (each within the scatter of the next).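

Compound 4 shows that a methoxyphenyl in a second position on the anilino nitrogen also separates from both halogen-bearing compounds, with a 2.5-fold lower number from compound 3 to compound 4 (0.40 log units; beyond the scatter) and a 3.3-fold lower number from compound 2 to compound 4 (0.52 log units; beyond the scatter) in this assay. The two methoxy isomers, however, cannot be told apart, with a 1.2-fold higher number from compound 1 to compound 4 (0.08 log units; within the scatter), so among these four compounds the 2-methoxyphenyl and 4-methoxyphenyl groups form one level and the 3-chlorophenyl and 3-(trifluoromethyl)phenyl groups another, with no compound going against that split. No measurement at hand offers an explanation for the split.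

Each step from a methoxyphenyl to a halogen-bearing group changes both the substituent and its position, so these compounds cannot separate the two effects. As far as these compounds go, how an unsubstituted phenyl, or an aryl ring carrying a hydroxyl or an amine, would fit this split remains open.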